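Working notes: from compound 2 to compound 4

A few compounds are considered here, and "the series" means these few. Any claim that something is new, unique, unknown or untested is made for them only; others in the source may bear on it.

Measured so far in a functional assay on NCI-H460 cells (Homo sapiens) for inhibition, read by MTT assay, with a stated time of 24 h, tested at 100 ug/mL (on this read-out higher numbers stand for more inhibition of growth at the one concentration tested and lower numbers for less inhibition of growth), for this series
- compound 1 `O=C(O)CCCCC(CCSC(=O)c1ccccc1)SC(=O)c1ccccc1` gives 72.8%
- compound 2 `O=C(CCCCC1CCSS1)Nc1ccc(OC(F)(F)F)cc1` gives 83%
- compound 3 `O=C(CCCCC1CCSS1)Nc1cccc2ccccc12` gives "not active" (no number reported)

Of the two compounds with a number, compound 2 stands highest in this assay and compound 1 lies lower by more than the scatter. Compound 3 carries no number and cannot be placed on that scale.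

Compound 4 `O=C(CCCCC(S)CCS)Nc1ccc(OC(F)(F)F)cc1` is still to be measured. It keeps the amide of compound 2 and carries this change (a group of 5 heavy atoms (3 carbon, 2 sulfur; no ring) in place of a group of 5 heavy atoms (3 carbon, 2 sulfur; one five-membered non-aromatic ring with 2 hetero atoms), on a saturated chain carbon, four bonds along the chain from a carbonyl carbon) so that the five-membered ring leaves and 1,3-disulfanylpropyl enters.

Within the data shown here, no measured pair isolates this change. Compound 1 also lacks the ring, differs elsewhere too and gives 72.8% on this read-out, so an open chain is not expected to remove the inhibition. Compound 3 keeps the ring and gives "not active" (no number reported) without a number, which goes against any simple link between ring and activity.

The expected a number 7 percentage points lower from compound 2 to compound 4 (within the scatter) is a small fall within the scatter. Compound 4 is estimated at 76% with 58% to 91% as the expected range.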

Compound 4, percent growth inhibition at one concentration: 65.1%
Beside the measured number, compound 4's estimate is 10.9 percentage points above it, and the stated range covers the measured number.
By their numbers in this assay, from the lowest: compounds 4 and 1 (each within the scatter of the next); then compound 2.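

In this assay, replacing the five-membered ring with 1,3-disulfanylpropyl, on a saturated chain carbon, four bonds along the chain from a carbonyl carbon, gives a number 17.9 percentage points lower from compound 2 to compound 4 (beyond the scatter). Among these compounds, this is the only single-place step so far, and it shows that the change at this position can be read on this scale, while the amide held constant in this pair still allows a measurable number without the ring, with compound 4 at 65.1%. No measurement at hand bears on what lies behind this step.

Open, on these data alone, is whether the step follows from losing the ring or from the free thiol hydrogens, which a 1,3-bis(methylsulfanyl)propyl group at the same place could separate. One concentration also leaves open how the pair would compare across a range of concentrations.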